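Removing one methoxy group from compound 3

The compounds below may be only part of what the source reports. "The series", "measured", "known", "first", "only" and "open" are said of these compounds alone.

Compound 1 `O=C1NCCN1c1ccc(S(=O)(=O)Nc2cccc(Cl)c2)cc1`: 55 nM
Compound 2 `COc1ccc(NS(=O)(=O)c2ccc(N3CCNC3=O)cc2)cc1`: 800 nM
Compound 3 `COc1cc(NS(=O)(=O)c2ccc(N3CCNC3=O)cc2)cc(OC)c1`: 78 nM

These compounds share one core and differ in the group on the sulfonamide nitrogen. In a functional assay on HT-29 cells (Homo sapiens) for antiproliferative activity, read by sulforhodamine B assay, with a stated time of 48 h (a lower number here means a stronger inhibitor, a higher number a weaker inhibitor), compound 3 gives 78 nM, which lies within the usual scatter of compound 1 at 55 nM and is clearly stronger than compound 2 at 800 nM. The next compound is compound 4 `COc1cccc(NS(=O)(=O)c2ccc(N3CCNC3=O)cc2)c1`. It differs from compound 3 by one change: hydrogen in place of methoxy on an aromatic carbon.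

Among the measured compounds shown here, no measured step makes exactly this change. The only one available, a 15-fold higher number from compound 1 to compound 2 (1.16 log units; beyond the scatter), swaps the chlorine-bearing group on the sulfonamide nitrogen for a methoxy-bearing one. That step is large and beyond the scatter, so this group can clearly matter, but the step does not fix a direction for the change here. Compound 4 keeps a methoxy group, and compound 2, which also carries one at a different place, gives 800 nM, so a shift towards a higher number seems more likely than the reverse. The expected step is a 1.9-fold higher number from compound 3 to compound 4 (0.28 log units; within the scatter), a small one close to the scatter. For compound 4 the estimated value is 150 nM, with an expected range from 50 nM to 500 nM.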

Compound 4, half-maximal inhibitory concentration: 120 nM
Beside the measured number, compound 4's estimate is 1.3-fold (0.10 log units) above it; measured number inside the range.
By their numbers in this assay, from the lowest: compounds 1, 3 and 4 (each within the scatter of the next, the first and the last beyond it); then compound 2.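

In this assay, taking one of the two methoxy groups off the ring on the sulfonamide nitrogen gives a 1.5-fold higher number from compound 3 to compound 4 (0.19 log units; within the scatter) and so leaves the two compounds indistinguishable, which means the second methoxy group is not needed for the activity seen in compound 3. Where the one remaining methoxy group sits counts for far more: 3-methoxyphenyl in place of 4-methoxyphenyl gives a 6.7-fold lower number from compound 2 to compound 4 (0.82 log units; beyond the scatter) even though the atoms are the same and only their arrangement differs, a contrast the earlier compounds could not show because none of them shared a single substituent in two places. Swapping the group at that same ring place gives a 2.2-fold higher number from compound 1 to compound 4 (0.34 log units; beyond the scatter) and this modest step, just beyond the scatter, shows that methoxy and chloro there lead to fairly similar numbers.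

The compounds shown leave open how a ring with no substituent at all would behave, and whether a different group in that place, such as an amine, a carboxylic acid or a longer ether chain, would match chloro or methoxy. No measurement here explains why the place of the methoxy group matters so much.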